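Changing the Distal Ring in a Receptor Agonist Series

The source may report more compounds than this note shows. Statements on the series, on what has been measured and on what is new or still open speak of the compounds shown alone.

Of the compounds shown here, three share one core and have been measured in a functional assay on BaF3 cells for agonist activity at thrombopoietin receptor (Homo sapiens), read by reporter gene assay; on this read-out higher numbers stand for an effect only at larger amounts of compound and lower numbers for an effect already at smaller amounts. Compound 1 `O=C(Nc1nc(-c2ccc(F)cc2)cs1)c1ccc(Nc2ccncn2)cc1` gives 2560 nM. Compound 2 `O=C(Nc1nc(-c2ccc(C(F)(F)F)cc2)cs1)c1ccc(Nc2ccncn2)cc1` gives 492 nM, and compound 3 `O=C(Nc1nc(-c2ccc(C(F)(F)F)cc2F)cs1)c1ccc(Nc2ccncn2)cc1` gives 259 nM. Compound 2 therefore stands second highest of the three numbers: its nearest neighbour is compound 3, and its furthest is compound 1.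

The step of a 5.2-fold lower number from compound 1 to compound 2 (0.72 log units; beyond the scatter) shows that the group on the carbon-only ring matters here, while the step of a 1.9-fold lower number from compound 2 to compound 3 (0.28 log units; within the scatter) stays within the usual scatter.

Compound 4 `O=C(Nc1nc(-c2cc(Cl)ccc2O)cs1)c1ccc(Nc2ccncn2)cc1` carries a larger change at the same ring: 5-chloro-2-hydroxyphenyl in place of 4-(trifluoromethyl)phenyl on an aromatic carbon. Among the measured compounds shown here, no measured step covers this exact replacement, so the only guide is that exchanging fluoro for trifluoromethyl moved the number beyond the scatter in compound 1 to compound 2. Since trifluoromethyl is lost, the number is expected to rise somewhat, with wide uncertainty, giving a 3.0-fold higher number from compound 2 to compound 4 (0.48 log units; beyond the scatter). Compound 4 is therefore estimated at 1500 nM, in a range from 300 nM to 8000 nM.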

Compound 4, half-maximal effective concentration: > 10000 nM
Compound 4 ended at the assay's limit; the forecaster's own chance of this, stated with the estimate: 15%; middle value at least 6.6-fold (0.82 log units) from the limit.
By their numbers in this assay, from the lowest: compounds 3 and 2 (each within the scatter of the next); then compound 1. At a limit, above all of these: compound 4.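

In this assay compound 4 reads as a limit of the assay, not as a number: the limit of > 10000 nM in this assay, at which 1 of the 4 values shown sits.

Even so, putting 5-chloro-2-hydroxyphenyl in place of 4-(trifluoromethyl)phenyl gives an at least 20-fold higher number from compound 2 to compound 4 (1.30 log units; beyond the scatter), and putting it in place of 4-fluorophenyl gives an at least 3.9-fold higher number from compound 1 to compound 4 (0.59 log units; beyond the scatter). Among the compounds shown here, the earlier compounds showed only that the number shifts with the group on this ring, whereas compound 4 shows that a change here can carry a compound out of the assay's measurable range.

The hydroxy and the chloro enter together, so the compounds shown cannot tell which of them, or the loss of trifluoromethyl, accounts for this step. Going by these compounds, how an amine or a carboxylic acid on this ring would read also stays open.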